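Nitro to methoxy swap on the aromatic ring

A few compounds are considered here, and "the series" means these few. Any claim that something is new, unique, unknown or untested is made for them only; others in the source may bear on it.

Measured so far in a functional assay on PC-3 cells (Homo sapiens) for cytotoxicity, read by MTT assay, with a stated time of 72 h; a lower number here means a stronger inhibitor, a higher number a weaker inhibitor:
compound 1, `COc1cc(/C=C/C(=O)/C=C/C2=C(C)CCCC2(C)C)ccc1O`, gives 21300 nM.
compound 2, `CC1=C(/C=C/C(=O)/C=C/c2ccc(O)c([N+](=O)[O-])c2)C(C)(C)CCC1`, gives only a limit, > 50000 nM.
compound 3, `CC1=C(/C=C/C(=O)/C=C/c2cccc([N+](=O)[O-])c2)C(C)(C)CCC1O`, gives 5800 nM.

The value of compound 2 is a limit of this assay and not a number (the limit of > 50000 nM in this assay, at which 1 of the 3 values shown sits). Compound 3 holds the lowest number of the two numbers recorded, with compound 1 nearest to it. Between compound 2 and compound 1 the change is methoxy in place of nitro on an aromatic carbon, and that change made a step of an at least 2.3-fold lower number from compound 2 to compound 1 (0.37 log units; beyond the scatter). The difference between the cores of compound 2 and compound 3 is not broken down here.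

Compound 4, `COc1cccc(/C=C/C(=O)/C=C/C2=C(C)C(O)CCC2(C)C)c1`, is not yet measured. It differs from compound 3 by methoxy in place of nitro on an aromatic carbon. In compound 1 the incoming methoxy sits ortho to a hydroxy group (1 heavy atom) and meta to a large group, whereas in compound 4 it sits only meta to a large group, so the change is the same kind of change as from compound 2 to compound 1, not the same one.

The step from compound 3 to compound 4 in this assay is expected to be a 2.3-fold lower number from compound 3 to compound 4 (0.37 log units; beyond the scatter), resting on the earlier step of an at least 2.3-fold lower number from compound 2 to compound 1 (0.37 log units; beyond the scatter), whose size is known only as a lower bound because of the limit (the limit of > 50000 nM in this assay, at which 1 of the 3 values shown sits). Compound 4 is therefore estimated at 2500 nM, with a likely range from 800 nM to 8000 nM.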

Compound 4, half-maximal inhibitory concentration: 6500 nM
Compound 4: the middle estimate sits 2.6-fold (0.41 log units) below what was measured; the range from low to high includes it.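

In this assay, methoxy in place of nitro on an aromatic carbon gives a 1.1-fold higher number from compound 3 to compound 4 (0.05 log units; within the scatter), so on this core the two groups are not told apart. Whether the step carries over unchanged from one core to the other remains unsettled: the same change on two cores in this assay, an at least 2.3-fold lower number (0.37 log units; beyond the scatter) from compound 2 to compound 1 and a 1.1-fold higher number (0.05 log units; within the scatter) from compound 3 to compound 4; the limit leaves it open whether they differ

Compound 2 is recorded only as a limit, > 50000 nM, and not as a number, so the earlier step is bounded on one side only and the pair gives no exact size to set against the new step.

The compounds shown leave open whether the swap would give a step of one size on other cores, since a single pair on each of two cores cannot separate the effect of the core from the swap itself. They also leave open whether another group on the same aromatic carbon of the core of compound 3, such as an amine or a carboxylic acid, would move the number in this assay beyond the scatter, and whether nitro and methoxy would stay indistinguishable elsewhere on the aromatic ring.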